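Chain extension on the aminoalkyl arm: compound 2 to compound 4

A few compounds are considered here, and "the series" means these few. Any claim that something is new, unique, unknown or untested is made for them only; others in the source may bear on it.

Measured compounds:
Compound 1, `Cc1ccc(Cn2ccnc2/C=N/Nc2nc(NCCN(C)C)c3ccccc3n2)cc1`, gives 1410 nM in a functional assay on HT-29 cells (Homo sapiens) for cytotoxicity, read by MTT assay, with a stated time of 72 h; a lower number here means a stronger inhibitor, a higher number a weaker inhibitor.
Compound 2, `CN(C)CCNc1nc(N/N=C/c2nccn2Cc2ccc(F)cc2)nc2ccccc12`, gives 930 nM in this assay.
Compound 3, `CN(C)CCNc1nc(N/N=C/c2nccn2Cc2cccc(Cl)c2Cl)nc2ccccc12`, gives 260 nM in this assay.

Compound 2 holds the second highest of the three numbers in this assay. Its nearest neighbour is compound 1: the step of a 1.5-fold lower number from compound 1 to compound 2 (0.18 log units; within the scatter) stays within the scatter, so the two values are not told apart. Compound 3 is further off, with a 3.6-fold lower number from compound 2 to compound 3 (0.55 log units; beyond the scatter); the related step of a 5.4-fold lower number from compound 1 to compound 3 (0.73 log units; beyond the scatter) points the same way.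

Compound 4, `CN(C)CCCNc1nc(N/N=C/c2nccn2Cc2ccc(F)cc2)nc2ccccc12`, differs from compound 2 by (dimethylamino)methyl in place of dimethylamino on a saturated chain carbon, two bonds along the chain from a nitrogen on an aromatic ring. Every measured step in this set changes the aryl group on the saturated chain carbon bound to an aromatic nitrogen; none of them alters the dimethylamino-bearing chain on the other side of the core. Going by the values given here, no measured step therefore bears on this change, and the set gives no ground for a shift in either direction. The expectation for compound 4 is a step of no size beyond the scatter, no change at the digits printed from compound 2 to compound 4 (within the scatter). Compound 4 is estimated at 930 nM in this assay, with a range from 400 nM to 2200 nM.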

Compound 4, half-maximal inhibitory concentration: 630 nM
Beside the measured number, compound 4's estimate is 1.5-fold (0.17 log units) above it; the range from low to high includes it.
By their numbers in this assay, from the lowest: compound 3; then compounds 4, 2 and 1 (each within the scatter of the next, the first and the last beyond it).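

In this assay the aminoalkyl arm now has its first reading: a 1.5-fold lower number from compound 2 to compound 4 (0.17 log units; within the scatter) leaves the two compounds not told apart, so (3-(dimethylamino)propyl)amino in place of (2-(dimethylamino)ethyl)amino does not register as a change with the 4-fluorophenyl group held fixed. The arm therefore joins the comparison as a position where this change gives no step beyond the scatter, while the steps beyond it in the set remain those to the 2,3-dichlorophenyl group of compound 3. Nothing at hand speaks to the origin of this result.

As far as these compounds go, whether the 3-(dimethylamino)propyl arm reads the same when paired with the 2,3-dichlorophenyl group stays open. Also open, from the compounds shown here alone, is the outcome with a longer chain, or with a pyrrolidine or morpholine in place of the dimethylamino group.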